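A sulfonyl group added to the ring nitrogen of compound 3

The source may report more compounds than this note shows. Statements on the series, on what has been measured and on what is new or still open speak of the compounds shown alone.

In a functional assay on QGY-7703 cells (Homo sapiens) for cytotoxicity, read by MTT assay, with a stated time of 24 h (on this read-out lower numbers stand for stronger inhibition and higher numbers for weaker inhibition), compound 3 (`O=C1/C(=C/c2cccnc2)CNC/C1=C\c1ccccc1F`) gives 8890 nM. That number lies within the scatter of compound 2 (`CN1C/C(=C\c2ccncc2)C(=O)/C(=C/c2ccccc2C(F)(F)F)C1`) at 4500 nM, while compound 1 (`CN1C/C(=C\c2ccc(C(F)(F)F)cc2)C(=O)/C(=C/c2cccnc2)C1`) stands clearly lower at 1660 nM.

Compound 4 (`N#Cc1ccc(S(=O)(=O)N2C/C(=C\c3cccnc3)C(=O)/C(=C/c3ccccc3F)C2)cc1`) departs from compound 3 at one place: (4-cyanophenyl)sulfonyl in place of hydrogen on an amine nitrogen in a ring. This puts (4-cyanophenyl)sulfonyl in place of hydrogen on an amine nitrogen in a ring. Among the measured compounds shown here, no two measured compounds differ in only one place, so the data offer no direct measure of such a change.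

The only hint is weak. Compound 1, at 1660 nM, carries a methyl group on that nitrogen and differs from compound 3 elsewhere too. Compound 2, at 4500 nM, also carries that methyl group yet goes against the hint by staying within the scatter of compound 3.

A moderate move toward stronger inhibition in this assay is expected, an estimated 3.6-fold lower number from compound 3 to compound 4 (0.55 log units; beyond the scatter). Compound 4 is estimated at 2500 nM, with an expected range from 700 nM to 8000 nM.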

Compound 4, half-maximal inhibitory concentration: 15800 nM
The estimate for compound 4 lay 6.3-fold (0.80 log units) below the measured number, outside the stated range (above it).
By their numbers in this assay, from the lowest: compound 1; then compounds 2, 3 and 4 (each within the scatter of the next, the first and the last beyond it).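

In this assay, among the compounds shown here, the first direct reading at the ring amine nitrogen is a 1.8-fold higher number from compound 3 to compound 4 (0.25 log units; within the scatter), for (4-cyanophenyl)sulfonyl in place of hydrogen. This step stays within the usual scatter, so the pair shows no separable effect of the change, even though a large group with its own aromatic ring enters at this nitrogen. No measurement shown here offers an explanation for this outcome.

The compounds shown leave open how an acetyl group or a benzyl group on that nitrogen would read in this assay. They also leave open whether the sulfonyl link or the 4-cyanophenyl part matters more, since the two enter together and a plain methanesulfonyl group on the same core would be needed to begin separating them.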